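This account rests on a few compounds, and the source may have more. Where it says the series, first, only, none or still open, it means among the compounds named here.

Measured in a physicochemical assay for lipophilicity; a lower number here means a more polar compound, a higher number a more lipophilic compound:
- Compound 1 `CCCCOC(=O)c1ccc(S(N)(=O)=O)cc1`: 2.34
- Compound 2 `CCCCCCCNC(=O)c1ccc(S(N)(=O)=O)cc1`: 2.57
- Compound 3 `CCOC(=O)c1cccc(S(N)(=O)=O)c1`: 1.11

Compound 3, at 1.11, stands lowest of the three in this assay. Compound 1 lies nearest to it at 2.34, and compound 2 lies furthest at 2.57. Both gaps are beyond the usual scatter.

The next compound to be measured is compound 4 `CCCOC(=O)c1cccc(S(N)(=O)=O)c1`. It differs from compound 3 in one place: methyl in place of hydrogen on a saturated chain carbon, two bonds along the chain from an oxygen next to a carbonyl group. In words, a methyl takes the place of a hydrogen on a saturated chain carbon, two bonds along the chain from an oxygen next to a carbonyl group, and the same difference can be read as ethyl to propyl, or ethoxy to propoxy.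

For the measured compounds named here, no two measured compounds differ in only one place, so the data offer no direct step as a guide. A rise in the number is nevertheless expected, of a size modestly beyond the scatter, and compound 4 is expected to stay well under the number of compound 1, which reads 2.34. The expected change is a number 0.49 log units higher from compound 3 to compound 4 (beyond the scatter). For compound 4 the estimated value is 1.6, with an expected range from 1.35 to 1.9.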

Compound 4, partition coefficient: 1.72
Compound 4: the middle estimate sits 0.12 log units below what was measured, within the range that was stated.
By their numbers in this assay, from the lowest: compound 3; then compound 4; then compounds 1 and 2 (each within the scatter of the next).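

In this assay, for the compounds shown here, the ethyl to propyl change gives a number 0.61 log units higher from compound 3 to compound 4 (beyond the scatter) and is the only change in this set that can be read alone: a methyl in place of hydrogen on a saturated chain carbon, two bonds along the chain from an oxygen next to a carbonyl group. Compound 1, compound 2 and compound 3 differ from one another in more than one place, so they could not give the size of any single change, whereas this step shows that one added methyl at this position gives a modest move that lies beyond the scatter. Nothing measured here accounts for the size of this step.

Going by these compounds, whether a longer chain at this place, such as butoxy in place of propoxy, would add a step of similar size remains open, as does whether an amine at the end of the chain would move the number the other way. One step also cannot show whether the same ethyl to propyl change would give a similar step on the core of compound 1 or compound 2.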